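The source may hold more compounds than are shown below. What is called first, only, known or untested is meant among the compounds shown, and "the series" means these compounds.

In an ADME assay on BaF3 cells (Mus musculus) for cytotoxicity, read by CellTiter-Glo and CCK-8 assay, with a stated time of 72 h (on this read-out lower numbers stand for stronger inhibition of growth and higher numbers for weaker inhibition of growth), compound 1 (`C=CS(=O)(=O)NCc1ccc(C(=O)Nc2ccc(C)c(Nc3nccc(-c4cccnc4)n3)c2)cc1`) gives 7710 nM and compound 2 (`CCC(=O)NCc1cccc(C(=O)Nc2ccc(C)c(Nc3nccc(-c4cccnc4)n3)c2)c1`) gives 4750 nM, two numbers that lie within the usual scatter of each other. Compound 3 (`C=CC(=O)NCc1ccc(C(=O)Nc2ccc(C)c(Nc3nccc(-c4cccnc4)n3)c2)cc1C(F)(F)F`) is reported only as a limit, > 10000 nM. Compound 4 (`C=CC(=O)N(CCN(C)C)Cc1ccc(C(=O)Nc2ccc(C)c(Nc3nccc(-c4cccnc4)n3)c2)cc1`) has not yet been measured. Compared with compound 1, it carries (2-(dimethylamino)ethyl)(vinylcarbonyl)amino in place of (vinylsulfonyl)amino on a saturated chain carbon bound to an aromatic carbon. Within the data shown here, no measured pair of compounds isolates this change, so the expectation rests only on the neighbouring values. Set against compound 1, compound 2 differs in its side chain and still gives 4750 nM, which suggests that such changes need not move the number far. A modest move towards stronger inhibition of growth is expected, and it may not clear the scatter. The expected step is a 1.9-fold lower number from compound 1 to compound 4 (0.28 log units; within the scatter). Compound 4 is estimated at 4000 nM, with an expected range from 1300 nM to 10000 nM.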

Compound 4, concentration for 50% growth inhibition: > 10000 nM
Compound 4: no number, only a limit (the forecaster's own chance of this, stated with the estimate: 20%); middle value at least 2.5-fold (0.39 log units) away from the limit.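

In this assay compound 4 is reported only as a limit, > 10000 nM, so (2-(dimethylamino)ethyl)(vinylcarbonyl)amino in place of (vinylsulfonyl)amino on a saturated chain carbon bound to an aromatic carbon yields no exact number. Going by these compounds, the pair can be read only as an at least 1.2-fold higher number from compound 1 to compound 4 (0.11 log units; that floor lies within the scatter), so this change gives no readable gain in inhibition of growth, and the true size of the step stays unknown. The result adds one more compound at the top of the measurable range: the limit of > 10000 nM in this assay, at which 2 of the 4 values shown sit.

The compounds shown leave open whether the 2-(dimethylamino)ethyl chain or the exchange of vinylsulfonyl for vinylcarbonyl sets this result, as the two differ together in this pair. On these data alone, it also remains open whether a morpholine or a longer chain at the end of that 2-(dimethylamino)ethyl chain would give a value inside the measurable range.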